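A few compounds are considered here, and "the series" means these few. Any claim that something is new, unique, unknown or untested is made for them only; others in the source may bear on it.

Measured compounds:
compound 1, `O=C1COc2ccc(-c3cccc(NS(=O)(=O)c4ccc(F)cc4)c3)cc2N1c1ccccc1`, 17700 nM
compound 2, `O=C1COc2ccc(-c3cnc(Cl)c(NS(=O)(=O)c4ccc(F)cc4)c3)cc2N1c1ccccc1`, 10300 nM
compound 3, `O=C1COc2ccc(-c3cccc(NS(=O)(=O)c4ccc(F)cc4)c3)cc2N1C1CC1`, > 40000 nM

In a functional assay on HeLa cells (Homo sapiens) for antiproliferative activity, read by MTT assay, with a stated time of 72 h (a lower number here means a stronger inhibitor, a higher number a weaker inhibitor), compound 1 gives 17700 nM. Compound 2 has a core that differs from that of compound 1 in a way not broken down here. In this assay compound 2 gives 10300 nM, a value within the scatter of compound 1. For compound 3 this assay reports only a limit, > 40000 nM. The change from compound 1 to compound 3 is cyclopropyl in place of phenyl on an amide-type nitrogen in a ring, and it made an at least 2.2-fold higher number from compound 1 to compound 3 (0.35 log units; beyond the scatter), the value of compound 3 sitting at the limit of > 40000 nM in this assay, at which 1 of the 3 values shown sits.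

Compound 4, `O=C1COc2ccc(-c3cnc(Cl)c(NS(=O)(=O)c4ccc(F)cc4)c3)cc2N1C1CC1`, is not yet measured. It carries the same change relative to compound 2, namely (cyclopropyl in place of phenyl on an amide-type nitrogen in a ring). Since the same change from compound 1 to compound 3 gave an at least 2.2-fold higher number from compound 1 to compound 3 (0.35 log units; beyond the scatter), a step of similar size or larger is expected from compound 2 to compound 4, around a 2.9-fold higher number from compound 2 to compound 4 (0.46 log units; beyond the scatter). Compound 4 is therefore estimated at 30000 nM in this assay.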

Compound 4, half-maximal inhibitory concentration: 7180 nM
Compound 4: the middle estimate sits 4.2-fold (0.62 log units) above what was measured; measured number outside the range, below it.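

In this assay, cyclopropyl in place of phenyl on the amide-type nitrogen in a ring gave a 1.4-fold lower number from compound 2 to compound 4 (0.16 log units; within the scatter), and this change did not carry over from one core to the other as a step of the same size: the same change on two cores in this assay, an at least 2.2-fold higher number (0.35 log units; beyond the scatter) from compound 1 to compound 3 and a 1.4-fold lower number (0.16 log units; within the scatter) from compound 2 to compound 4, at least 3.2-fold (0.51 log units) apart, beyond the scatter of two such steps

The value of compound 3, > 40000 nM, is a limit and not a number, so the gap between the two steps is bounded on one side only. Two cores also do not show how this change would read on any further core.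

Open, going by these compounds, is how a methyl group or a longer chain on that nitrogen would read on either core. Also open, on these data alone, is how the step would read with an amine in place of the chloro group of compound 2 and compound 4.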